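The source may report more compounds than this note shows. Statements on the series, on what has been measured and on what is new or still open speak of the compounds shown alone.

Compound 1 `Oc1ccccc1CNc1ccc(-c2ccc(OC(F)(F)F)cc2)cc1` gives "not active" (no number reported) in a functional assay on Jurkat cells (Homo sapiens) for activation, with a stated time of 24 h (on this read-out higher numbers stand for an effect only at larger amounts of compound and lower numbers for an effect already at smaller amounts), with no number reported.
Compound 2 `Oc1ccccc1CNc1ccc(-c2ccccc2)nc1` gives 840 nM in this assay.

Within the data shown here, compound 2 therefore holds the only numerical value in this assay; compound 1 came out as not active, and since compound 1 differs from compound 2 in more than one place, no single step links the two. Compound 3 `COc1ccc(-c2ccc(NCc3ccccc3O)cn2)cc1` differs from compound 2 by methoxy in place of hydrogen on an aromatic carbon. No measured pair among these compounds shows what such a change does, so the size of the step in this assay rests on judgement alone. The expectation is a small step, more likely toward weaker activation than toward stronger, and possibly no step beyond the usual scatter. On that basis compound 3 is expected to give about 1200 nM in this assay, within a range of 400 nM to 4000 nM, which would mean an estimated step of a 1.4-fold higher number from compound 2 to compound 3 (0.15 log units; within the scatter).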

Compound 3, half-maximal effective concentration: 4760 nM
Beside the measured number, compound 3's estimate is 4.0-fold (0.60 log units) below it; measured number above the stated range.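

Methoxy in place of hydrogen on an aromatic carbon, para to a large group, is the only single change measured here, and in this assay it gives a 5.7-fold higher number from compound 2 to compound 3 (0.75 log units; beyond the scatter). This position is therefore not indifferent to substitution, as this one change requires larger amounts of compound for the effect, although compound 3 still gives a number rather than coming out as not active. Nothing in the information available explains the size of this step.

From the compounds shown here alone, whether a hydroxyl group, a fluorine atom or an ethoxy group at this place would shift the number as far as methoxy does remains open. So does the question of whether methoxy elsewhere on the same six-membered ring would give a step of similar size.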